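Formyl in Place of Hydroxymethyl on Three Inactive Analogues

The source may hold more compounds than are shown below. What is called first, only, known or untested is meant among the compounds shown, and "the series" means these compounds.

Compound 1, `CC1(C)O[C@H]2CC[C@@](C)(O)[C@@H](CC[C@@H]3C(CO)=CC[C@H]4[C@H](CC[C@]4(C)O)C3(C)C)[C@]2(C)CCC1=O`, reaches only a limit in a functional assay on MDA-MB-231 cells (Homo sapiens) for antiproliferative activity, read by MTT assay, with a stated time of 72 h; on this read-out higher numbers stand for weaker inhibition and lower numbers for stronger inhibition: > 50000 nM.
Compound 2, `CC1(C)O[C@H]2CC[C@@](C)(O)[C@@H](CC[C@@H]3C(CO)=CC[C@H]4[C@H](CC[C@]4(C)O)C3(C)C)[C@]2(C)CC[C@@H]1O`, likewise reaches only a limit in this assay: > 50000 nM.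
Compound 3, `CC1(C)O[C@H]2CC[C@@](C)(O)[C@@H](CC[C@@H]3C(C=O)=CC[C@H]4[C@H](CC[C@]4(C)O)C3(C)C)[C@]2(C)CCC1=O`, also reaches only a limit in this assay: > 50000 nM.

None of the three measured compounds yields a number in this assay; each result is a limit of the assay. The change from compound 1 to compound 3 is formyl in place of hydroxymethyl on a double-bonded ring carbon. Its size in this assay is a step that the two limits leave unreadable from compound 1 to compound 3, since both ends of the step sit at the limit of > 50000 nM in this assay, at which 3 of the 3 values shown sit. Compound 2 shares the core of compound 1 but differs from it in more than one place, and the difference between the two cores is not broken down here.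

Compound 4, `CC1(C)O[C@H]2CC[C@@](C)(O)[C@@H](CC[C@@H]3C(C=O)=CC[C@H]4[C@H](CC[C@]4(C)O)C3(C)C)[C@]2(C)CC[C@@H]1O`, has not yet been measured. Among the compounds with values here, it differs from compound 2 by formyl in place of hydroxymethyl on a double-bonded ring carbon, the same change as the one from compound 1 to compound 3, made at the same place on the seven-membered ring. Because all three measured values sit at the limit of > 50000 nM in this assay, at which 3 of the 3 values shown sit, there is no readable step to carry over. The step from compound 2 to compound 4 in this assay is expected to be a step that the limit leaves unreadable from compound 2 to compound 4, meaning no movement that the assay can resolve. Compound 4 is therefore estimated to give 100000 nM in this assay, most likely again as a limit, with the number, if one appears, expected between 30000 nM and 500000 nM.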

Compound 4, half-maximal inhibitory concentration: > 50000 nM
Compound 4 was reported as a limit; the forecaster's own chance of this, stated with the estimate: 90%; the middle value is on the limit's open side.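

Compound 4, like compound 2, gives only a limit in this assay, and no step can be read from the one to the other, so formyl in place of hydroxymethyl again has no readable size: the limit of > 50000 nM in this assay, at which 4 of the 4 values shown sit.

The compounds shown leave open whether formyl and hydroxymethyl differ at all in this assay, and whether any change to the shared core would yield a number there.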